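Chloro for dimethylamino on the aromatic ring of compound 3

This account rests on a few compounds, and the source may have more. Where it says the series, first, only, none or still open, it means among the compounds named here.

In a functional assay on SMMC-7721 cells (Homo sapiens) for cytotoxicity, read by MTT assay, with a stated time of 72 h (a lower number here means a stronger inhibitor, a higher number a weaker inhibitor), compound 1 `CC(C)=C1C(=O)N(c2ccc(Cl)cc2)N(c2ccc(Cl)cc2)C1=O` gives 45600 nM and compound 2 `CCC(C)=C1C(=O)N(c2ccc(Cl)cc2)N(c2ccc(Cl)cc2)C1=O` gives 49200 nM. Compound 3 `CN(C)c1ccc(C=C2C(=O)N(c3ccc(Cl)cc3)N(c3ccc(Cl)cc3)C2=O)cc1` stands at > 128000 nM, which is a limit of the assay and not a number.

Compound 4 `O=C1C(=Cc2ccc(Cl)cc2)C(=O)N(c2ccc(Cl)cc2)N1c1ccc(Cl)cc1` carries chloro in place of dimethylamino on an aromatic carbon. For the measured compounds named here, the one measured step, a 1.1-fold higher number from compound 1 to compound 2 (0.03 log units; within the scatter), lies on a saturated chain carbon elsewhere in the molecule and offers no direct guide to this change. A lower number is nevertheless expected in this assay, near the level of compound 1 at 45600 nM. The estimated change is an at least 2.5-fold lower number from compound 3 to compound 4 (0.40 log units; beyond the scatter). For compound 4 the estimated value is 50000 nM, with an expected range from 16000 nM to 128000 nM.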

Compound 4, half-maximal inhibitory concentration: 30900 nM
Compound 4: the middle estimate sits 1.6-fold (0.21 log units) above what was measured; the measured number falls inside the stated range.
By their numbers in this assay, from the lowest: compounds 4, 1 and 2 (each within the scatter of the next). At a limit, above all of these: compound 3.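

In this assay, for the compounds shown here, going from 4-(dimethylamino)phenyl to 4-chlorophenyl gives an at least 4.1-fold lower number from compound 3 to compound 4 (0.61 log units; beyond the scatter), the only measured change on this aromatic carbon. Compound 4 therefore gives a number with a 4-chlorophenyl group, whereas compound 3 gives only a limit of the assay. The step remains a bound, because the value of compound 3 is a limit: the limit of > 128000 nM in this assay, at which 1 of the 4 values shown sits.

The compounds shown leave open how a methoxy group, a carboxylic acid or a primary amine on this aromatic carbon would read. They also leave open how an unsubstituted phenyl would compare with compound 4.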